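Amide aryl swap, cytotoxicity notes

The compounds below may be only part of what the source reports. "The series", "measured", "known", "first", "only" and "open" are said of these compounds alone.

compound 1, `CC(C)n1ncc2c(C(=O)Nc3ccncc3)cc(-c3cccs3)nc21`: 6300 nM
compound 2, `CC(C)n1ncc2c(C(=O)Nc3ccncn3)cc(-c3ccsc3)nc21`: > 200000 nM (a limit of the assay, not a number)

Among the compounds with values here, in an ADME assay on LLC-MK2 cells (Macaca mulatta) for cytotoxicity, read by spectrophotometry and crystal violet staining, with a stated time of 4 days (on this read-out higher numbers stand for lower toxicity in this test and lower numbers for higher toxicity in this test), compound 1 gives 6300 nM, the only measured number in the set. For compound 2 the result > 200000 nM is a limit of the assay; it sits at the limit of > 200000 nM in this assay, at which 1 of the 2 values shown sits. Within the data shown here, no two measured compounds differ in a single place, so no measured step is available.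

Compound 3, `CC(C)n1ncc2c(C(=O)Nc3ccccc3S(N)(=O)=O)cc(-c3cccs3)nc21`, has not yet been measured in this assay. It differs from compound 1 in one place: 2-sulfamoylphenyl in place of pyridin-4-yl on an amide-type nitrogen. Among the measured compounds shown here, with no measured step to lean on, the expected step is a 2.4-fold higher number from compound 1 to compound 3 (0.38 log units; beyond the scatter), toward lower toxicity, but of a size that may not go beyond the usual scatter. Compound 3 is expected at 15000 nM, with a range of 4000 nM to 60000 nM.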

Compound 3, half-maximal cytotoxic concentration: 25000 nM
Estimate against measurement, compound 3: 1.7-fold (0.22 log units) below, within the range that was stated.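

In this assay, within the data shown here, this is the first single-place change, and swapping pyridin-4-yl for 2-sulfamoylphenyl on the amide-type nitrogen gives a 4.0-fold higher number from compound 1 to compound 3 (0.60 log units; beyond the scatter). This position therefore affects the read-out, with the change here moving it toward lower toxicity in this test. The swap replaces a ring bearing one hetero atom with a carbon-only ring and also adds the sulfamoyl group, and nothing measured here gives a cause for the step.

The compounds shown leave open whether the step follows from the loss of the ring nitrogen or the arrival of the sulfamoyl group; a plain phenyl, or a phenyl carrying an amine or a carboxylic acid, on the same nitrogen would help to separate the two. Going by these compounds, whether the step carries over to other substituents on the shared core also remains open.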